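Amine-chain swap in the antiproliferative series: notes on compound 4

The source may hold more compounds than are shown below. What is called first, only, known or untested is meant among the compounds shown, and "the series" means these compounds.

Measured so far in a functional assay on DU-145 cells (Homo sapiens) for antiproliferative activity, read by MTT assay, with a stated time of 48 h; on this read-out higher numbers stand for weaker inhibition and lower numbers for stronger inhibition:
compound 1, `COc1cc(C(=O)/C=C/c2ccc(OCCCC(=O)NCCCNCCCCN)cc2)cc(OC)c1OC`, gives > 100000 nM, a limit of the assay.
compound 2, `COc1ccc(/C=C/C(=O)c2cc(OC)c(OC)c(OC)c2)cc1OCCCC(=O)NCCCNCCCCN`, gives > 100000 nM, a limit of the assay.
compound 3, `COc1cc(C(=O)/C=C/c2ccc(OCCCC(=O)NCCCCNCCCN)cc2)cc(OC)c1OC`, gives 54800 nM.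

Compound 3 differs from compound 1 by ((3-aminopropyl)amino)methyl in place of (4-aminobutyl)amino on a saturated chain carbon, three bonds along the chain from an amide-type nitrogen; this change gave an at least 1.8-fold lower number from compound 1 to compound 3 (0.26 log units; that floor lies within the scatter). The difference between the core of compound 1 and the core of compound 2 is not broken down here. Compound 2 sits at the limit of > 100000 nM in this assay, at which 2 of the 3 values shown sit.

Compound 4, `COc1ccc(/C=C/C(=O)c2cc(OC)c(OC)c(OC)c2)cc1OCCCC(=O)NCCCCNCCCN`, has not yet been measured in this assay. It differs from compound 2 by ((3-aminopropyl)amino)methyl in place of (4-aminobutyl)amino on a saturated chain carbon, three bonds along the chain from an amide-type nitrogen, the same change as between compound 1 and compound 3, at the same place.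

A step of about the same size is expected from compound 2 to compound 4, an at least 1.4-fold lower number from compound 2 to compound 4 (0.15 log units; that floor lies within the scatter), resting on compound 1 to compound 3 with an at least 1.8-fold lower number from compound 1 to compound 3 (0.26 log units; that floor lies within the scatter). Compound 2 gives only a limit, and compound 4 may likewise return only a limit. For compound 4 the estimate is 70000 nM, expected within 30000 nM to 150000 nM.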

Compound 4, half-maximal inhibitory concentration: 99300 nM
Compound 4: the middle estimate sits 1.4-fold (0.15 log units) below what was measured; the range from low to high includes it.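

The swap to ((3-aminopropyl)amino)methyl from (4-aminobutyl)amino gave a number no higher from compound 2 to compound 4 (the limit leaves the size open), so it can be set beside the earlier step only loosely: the same change on two cores in this assay, an at least 1.8-fold lower number (0.26 log units; that floor lies within the scatter) from compound 1 to compound 3 and a number no higher (the limit leaves the size open) from compound 2 to compound 4; the limit leaves it open whether they differ. In this assay compound 4 gives 99300 nM, and this does not go against the direction seen on the core of compound 1. It does not show that the change carries over from one core to the other at a matching size, since the comparison rests on a limit: the limit of > 100000 nM in this assay, at which 2 of the 4 values shown sit.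

Still open, as far as these compounds go, is how either core would respond to a longer polyamine chain, or to a carboxylic acid in place of the amine chain.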